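Sulfonamide aryl variation on a triazole thioether series

The source may report more compounds than this note shows. Statements on the series, on what has been measured and on what is new or still open speak of the compounds shown alone.

Compound 1 `O=S(=O)(CSc1nnc(Br)n1Cc1ccc(Br)c2ccccc12)Nc1cc(Cl)cnc1Cl`: 2790 nM
Compound 2 `O=S(=O)(CSc1nnc(Br)n1Cc1ccc(Br)c2ccccc12)Nc1ccc(Br)nc1Br`: 5410 nM

Of the compounds shown here, two of the shared core have been measured in an assay on HEK293 cells for inhibition of solute carrier family 22 member 12 (Homo sapiens); a lower number here means a stronger inhibitor, a higher number a weaker inhibitor; they differ only in the halogenated pyridinyl on the sulfonamide nitrogen. Among the measured compounds shown here, compound 2 gives 5410 nM in this assay, and its only neighbour is compound 1 at 2790 nM; the step of a 1.9-fold higher number from compound 1 to compound 2 (0.29 log units; within the scatter) lies within the scatter, so the two numbers are indistinguishable.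

Compound 3 `O=S(=O)(CSc1nnc(Br)n1Cc1ccc(Br)c2ccccc12)Nc1cnccc1I` carries the change (4-iodopyridin-3-yl in place of 2,6-dibromopyridin-3-yl on a sulfonamide nitrogen). For the measured compounds named here, the one measured step, from compound 1 to compound 2, also exchanges halogens on this pyridinyl and is within the scatter; no step reaches beyond it. The step of a 1.4-fold lower number from compound 2 to compound 3 (0.13 log units; within the scatter) is therefore expected to stay within the scatter, with no direction assigned. Going by the values given here, for compound 3 the estimate in this assay is 4000 nM, with a range from 1200 nM to 13000 nM, kept wide because only the step of a 1.9-fold higher number from compound 1 to compound 2 (0.29 log units; within the scatter) informs it.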

Compound 3, half-maximal inhibitory concentration: 10600 nM
Compound 3: the middle estimate sits 2.7-fold (0.42 log units) below what was measured; measured number inside the range.
By their numbers in this assay, from the lowest: compounds 1, 2 and 3 (each within the scatter of the next, the first and the last beyond it).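

In this assay, among the compounds shown here, 4-iodopyridin-3-yl in place of 2,5-dichloropyridin-3-yl on the sulfonamide nitrogen gives the first step at this position beyond the scatter, a 3.8-fold higher number from compound 1 to compound 3 (0.58 log units; beyond the scatter), so the choice of halogenated pyridinyl here can shift the number, though only modestly. The same group in place of 2,6-dibromopyridin-3-yl stays within the scatter, a 2.0-fold higher number from compound 2 to compound 3 (0.29 log units; within the scatter), so compound 2 cannot be told apart from either of the other two, and only the two ends of the set separate. Nothing available bears on the origin of this step.

Iodine identity, halogen placement and halogen count all change together in these compounds, so which of them matters remains unresolved. Also open, from the compounds shown here alone, is how a plain phenyl, or a pyridinyl carrying a methoxy group or a nitrile, would read on this nitrogen.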